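Thiophene Replaces Fluorophenyl in a Serotonin Receptor Amide

The source may report more compounds than this note shows. Statements on the series, on what has been measured and on what is new or still open speak of the compounds shown alone.

Of the compounds shown here, two share one core and have been measured in an assay for binding affinity to 5-hydroxytryptamine receptor 1F (Homo sapiens), read by radioligand binding; on this read-out lower numbers stand for stronger inhibition and higher numbers for weaker inhibition. Compound 1 `CC(=O)Nc1cc2c(C3CCN(C)CC3)c[nH]c2cn1`, which carries a small acetyl amide, gives 210 nM. Compound 2 `CN1CCC(c2c[nH]c3ccc(NC(=O)c4cccc(F)c4)nc23)CC1`, with an aromatic amide instead, gives 11 nM, the lowest of the two numbers, and its gap to compound 1 lies beyond the scatter. Compound 3 `CN1CCC(c2c[nH]c3ccc(NC(=O)c4cccs4)nc23)CC1` keeps everything else and differs only by thiophen-2-yl in place of 3-fluorophenyl on a carbonyl carbon. Among the measured compounds shown here, no measured pair shows this change, so the step from compound 2 to compound 3 is expected to be small, a 1.4-fold higher number from compound 2 to compound 3 (0.13 log units; within the scatter), not clearly beyond the scatter. Compound 3 is therefore estimated at 15 nM, likely between 5 nM and 50 nM.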

Compound 3, inhibition constant: 7.1 nM
Compound 3: the middle estimate sits 2.1-fold (0.32 log units) above what was measured, within the range that was stated.
By their numbers in this assay, from the lowest: compounds 3 and 2 (each within the scatter of the next); then compound 1.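

In this assay, putting thiophen-2-yl in place of 3-fluorophenyl on a carbonyl carbon gives a 1.5-fold lower number from compound 2 to compound 3 (0.19 log units; within the scatter), so this pair cannot be told apart. At this position, a five-membered aromatic ring with one hetero atom therefore serves as well as a six-membered aromatic ring of carbon only. Nothing available explains why the two rings match. Still open, from the compounds shown here alone, is whether an aromatic ring is needed here at all, since a cyclohexyl group or a dimethylamino group on the same carbonyl carbon could behave differently.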